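The compounds below may be only part of what the source reports. "The series", "measured", "known", "first", "only" and "open" are said of these compounds alone.

In an assay on CHO cells for binding affinity to integrin alpha-1 (Homo sapiens), read by WST assay, with a stated time of 2 h (a higher number here means that more compound is needed for the effect, a lower number that less compound is needed), compound 1 `O=C(c1ccccc1)c1cccc(NS(=O)(=O)c2ccccc2)c1` is recorded as "not active" (no number reported) and yields no number. Compound 2 `O=C(c1ccccc1)c1cccc(NS(=O)(=O)c2ccc(Br)cc2)c1` gives 16000 nM in this assay, the only numerical result in the set, so it stands alone as the reference point. Compound 3 `O=C(c1ccccc1)c1cccc(NS(=O)(=O)c2ccc(I)cc2)c1` differs from compound 2 by iodo in place of bromo on an aromatic carbon. Going by the values given here, with no pair of measured values to show how such a change plays out, only a small step is expected from compound 2 to compound 3, a 1.3-fold lower number from compound 2 to compound 3 (0.12 log units; within the scatter), not beyond the usual scatter. Compound 3 is therefore estimated at 12000 nM, with a range from 4000 nM to 40000 nM.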

Compound 3, half-maximal effective concentration: 40000 nM
Estimate against measurement, compound 3: 3.3-fold (0.52 log units) below; the range from low to high includes it.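

The result shows that the choice of halogen on this aromatic carbon matters in this assay: iodo in place of bromo gives a 2.5-fold higher number from compound 2 to compound 3 (0.40 log units; beyond the scatter). For these two compounds, then, the heavier halogen goes with the higher number, so more of compound 3 is needed for the effect. Nothing available here explains this step. Open, as far as these compounds go, is how chloro, fluoro, an amine or a carboxylic acid on the same carbon would read in this assay. Also open, from the compounds shown here alone, is whether any group there gives a much lower number.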